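Methoxy for Fluoro Examined on Two Related Cores

The source may hold more compounds than are shown below. What is called first, only, known or untested is meant among the compounds shown, and "the series" means these compounds.

Measured so far:
Compound 1, `COC(=O)N1[C@@H]2C=C[C@@](OC)(C(=O)c3c2cc(OC)c(OC)c3OCc2ccc(OC)cc2)N1C(=O)OC`, gives > 300 ug/mL in an ADME assay on KB cells (Homo sapiens) for cytotoxicity; on this read-out higher numbers stand for an effect only at larger amounts of compound and lower numbers for an effect already at smaller amounts; this value is a limit of the assay.
Compound 2, `COC(=O)N1[C@@H]2C=C[C@@](OC)(C(=O)c3c2cc(OC)c(OC)c3OCc2ccc(F)cc2)N1C(=O)OC`, gives 56.6 ug/mL in this assay.
Compound 3, `COc1cc2c(c(OCc3ccc(F)cc3)c1OC)C(=O)[C@]1(OC)C=C[C@H]2N(C(=O)OCC(C)C)N1C(=O)OCC(C)C`, gives > 300 ug/mL in this assay; this value is a limit of the assay.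

Compound 1 and compound 2 share one core and differ only by methoxy in place of fluoro on an aromatic carbon. That change produced an at least 5.3-fold higher number from compound 2 to compound 1 (0.72 log units; beyond the scatter), a step that can only be given as a bound because of the limit of > 300 ug/mL in this assay, at which 2 of the 3 values shown sit.

Compound 3 carries a different core; the difference between the two cores is not broken down here. Compound 4, `COc1ccc(COc2c(OC)c(OC)cc3c2C(=O)[C@]2(OC)C=C[C@H]3N(C(=O)OCC(C)C)N2C(=O)OCC(C)C)cc1`, has not yet been measured in this assay. It differs from compound 3 by methoxy in place of fluoro on an aromatic carbon, the same change as that from compound 2 to compound 1, at the same place.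

For compound 4 a step that the limit leaves unreadable from compound 3 to compound 4 is expected. This expectation rests on the step of an at least 5.3-fold higher number from compound 2 to compound 1 (0.72 log units; beyond the scatter), which ran towards higher numbers. It also rests on compound 3, whose value in this assay, > 300 ug/mL, is already a limit. Compound 4 is therefore estimated at 450 ug/mL, between 250 ug/mL and 1200 ug/mL.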

Compound 4, concentration for half-maximal effect: 47.9 ug/mL
The estimate for compound 4 lay 9.4-fold (0.97 log units) above the measured number, and the stated range ends above it.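

In this assay, methoxy in place of fluoro on the 4-fluorobenzyl group gave an at least 6.2-fold lower number from compound 3 to compound 4 (0.79 log units; beyond the scatter), which runs in the opposite direction to the step seen on the other core. The change therefore did not carry over from one core to the other in this series: the same change on two cores in this assay, an at least 5.3-fold higher number (0.72 log units; beyond the scatter) from compound 2 to compound 1 and an at least 6.2-fold lower number (0.79 log units; beyond the scatter) from compound 3 to compound 4, at least 33-fold (1.52 log units) apart, beyond the scatter of two such steps

With only one pair on each core, this shows that the direction of the change differed between these two cores, but it gives the size of each step only as a bound and does not show which feature of the cores lies behind the difference: the limit of > 300 ug/mL in this assay, at which 2 of the 4 values shown sit.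

The compounds shown leave open how an amine or a carboxylic acid in place of fluoro would behave on these two cores. They also leave open which direction the methoxy for fluoro change would take on a third core, such as one carrying a longer chain on its carbamate groups.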